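Three Cytotoxicity Limits and an Ethyl Amide Question

A few compounds are considered here, and "the series" means these few. Any claim that something is new, unique, unknown or untested is made for them only; others in the source may bear on it.

Compound 1 `CCCc1cc(CNC(=O)c2cc3nc(C)c([C@H](OC(C)(C)C)C(=O)O)c(-c4cc(F)c5c(c4C)CCCO5)n3n2)ccc1F`: in an ADME assay on MT2 cells (Homo sapiens) for cytotoxicity (on this read-out higher numbers stand for lower toxicity in this test and lower numbers for higher toxicity in this test), compound 1 gives > 20000 nM, a limit of the assay.
Compound 2 `Cc1nc2cc(C(=O)NCc3ccc(F)c(C4CC4)c3)nn2c(-c2cc(F)c3c(c2C)CCCO3)c1[C@H](OC(C)(C)C)C(=O)O`: in this assay compound 2 gives > 40000 nM, a limit of the assay.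
Compound 3 `Cc1nc2cc(C(=O)NCc3ccc(F)cc3S(C)(=O)=O)nn2c(-c2cc(F)c3c(c2C)CCCO3)c1[C@H](OC(C)(C)C)C(=O)O`: in this assay compound 3 gives > 40000 nM, a limit of the assay.

Compound 3 stands at the limit of > 40000 nM in this assay, at which 2 of the 3 values shown sit. Compound 1 stands at the limit of > 20000 nM in this assay, at which 1 of the 3 values shown sits. None of the three compounds yields a number, so the three measured steps, a step that the two limits leave unreadable from compound 1 to compound 2, a step that the two limits leave unreadable from compound 1 to compound 3 and a step that the two limits leave unreadable from compound 2 to compound 3, have no readable size in this assay.

Compound 4 `CCCNC(=O)c1cc2nc(C)c([C@H](OC(C)(C)C)C(=O)O)c(-c3cc(F)c4c(c3C)CCCO4)n2n1` differs from compound 3 by ethyl in place of 4-fluoro-2-(methylsulfonyl)phenyl on a saturated chain carbon bound to an amide-type nitrogen. Within the data shown here, only the steps from compound 1 and compound 2 to compound 3 touch the same place, and they bear on the new change only in showing that every variation there so far has left the read-out at a limit. For compound 4 a limit is likewise expected because the limit of > 40000 nM in this assay, at which 2 of the 3 values shown sit, holds two of the three values shown. Compound 4 is therefore expected to give 40000 nM in this assay, in a range from 20000 nM to 80000 nM. This estimate corresponds to a number no higher from compound 3 to compound 4 (the limit leaves the size open), expected to be nothing beyond the scatter.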

Compound 4, half-maximal cytotoxic concentration: > 40000 nM
Compound 4 gave a limit, no number (the forecaster's own chance of this, stated with the estimate: 85%); the middle value sits exactly at the limit.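

Among these compounds, compound 1, compound 2, compound 3 and compound 4 all sit at limits in this assay, and no step from compound 4 to any of the other three can be read. The compounds shown leave open what half-maximal cytotoxic concentration any of them actually has.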